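A few compounds are considered here, and "the series" means these few. Any claim that something is new, unique, unknown or untested is made for them only; others in the source may bear on it.

Measured in a functional assay on HeLa cells (Homo sapiens) for cytotoxicity, read by sulforhodamine B assay; a higher number here means a weaker inhibitor, a lower number a stronger inhibitor:
- compound 1 `Cc1ccc(S(=O)(=O)NC(C2=CC(=O)c3c(O)ccc(O)c3C2=O)C(C)C)cc1`: 4850 nM
- compound 2 `CC(C)C(NS(=O)(=O)c1cccc(Br)c1)C1=CC(=O)c2c(O)ccc(O)c2C1=O`: 860 nM
- compound 3 `Cc1ccc(S(=O)(=O)NC(C)C2=CC(=O)c3c(O)ccc(O)c3C2=O)cc1`: 5340 nM

Compound 3, at 5340 nM, cannot be told apart from compound 1, at 4850 nM. Both numbers stand well above that of compound 2, at 860 nM.

The next compound, compound 4 `CC(NS(=O)(=O)c1ccc(Br)cc1)C1=CC(=O)c2c(O)ccc(O)c2C1=O`, differs from compound 3 in a single substituent: bromo in place of methyl on an aromatic carbon. This is bromo in place of methyl on an aromatic carbon, para to a large group, so 4-methylphenyl becomes 4-bromophenyl.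

For the measured compounds named here, two measured steps bear on this change. The closer one is a 5.6-fold lower number from compound 1 to compound 2 (0.75 log units; beyond the scatter), where 3-bromophenyl replaces 4-methylphenyl on the sulfonyl sulfur. It also trades methyl for bromo, though the bromo group sits elsewhere on the ring. The other is a 1.1-fold higher number from compound 1 to compound 3 (0.04 log units; within the scatter), methyl in place of isopropyl on the chain, and it lies within the scatter. That gives some reason to carry the first step over to the methyl compounds, but no measured compound has the 4-bromophenyl group, so a somewhat smaller step towards a lower number is expected.

The estimated change is a 3.0-fold lower number from compound 3 to compound 4 (0.47 log units; beyond the scatter). For compound 4 the expected value is 1800 nM, with an estimated range from 700 nM to 4500 nM.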

Compound 4, half-maximal inhibitory concentration: 5210 nM
Estimate against measurement, compound 4: 2.9-fold (0.46 log units) below; measured number outside the range, above it.
By their numbers in this assay, from the lowest: compound 2; then compounds 1, 4 and 3 (each within the scatter of the next).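

In this assay, putting bromo in place of methyl on this aromatic carbon, so that 4-methylphenyl becomes 4-bromophenyl, gives a 1.0-fold lower number from compound 3 to compound 4 (0.01 log units; within the scatter) on the compounds with a methyl on the chain, so at this place the swap of the two groups makes no difference that can be read. This also means that a 5.6-fold lower number from compound 1 to compound 2 (0.75 log units; beyond the scatter) cannot be credited to the presence of a bromo group on the ring alone, since that step placed the bromo differently, as 3-bromophenyl, and on the compounds with an isopropyl on the chain. No measurement shown gives a reason for either outcome.

The compounds shown do not separate the place of the bromo from the chain it is paired with, so it stays open whether 3-bromophenyl would lower the number with a methyl on the chain, and whether 4-bromophenyl would do so with an isopropyl there. Going by these compounds, it is also open how a methoxy group or an amine would behave on this same aromatic carbon.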